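The source may hold more compounds than are shown below. What is called first, only, known or untested is meant among the compounds shown, and "the series" means these compounds.

Values measured so far in a physicochemical assay for lipophilicity, using the shake flask method, at pH 7.4; a higher number here means a more lipophilic compound, a lower number a more polar compound:

- compound 1 `CCCC(Oc1ccc(-n2cc(F)cn2)cc1)c1ccc(C(=O)NCCC(=O)O)cc1`: 2
- compound 2 `CCCC(Oc1ccc(-n2cc(Cl)cn2)cc1)c1ccc(C(=O)NCCC(=O)O)cc1`: 2.6

Compound 2 holds the higher of these two values, 2.6. Compound 3 `CCCC(Oc1ccc(-n2cc(C(F)(F)F)cn2)cc1)c1ccc(C(=O)NCCC(=O)O)cc1` is not yet measured and differs from it in one group: trifluoromethyl in place of chloro on an aromatic carbon. For the measured compounds named here, the only measured step that bears on this is a number 0.60 log units higher from compound 1 to compound 2 (beyond the scatter), a modest one, with chloro in place of fluoro on an aromatic carbon. It concerns a different swap at the same place, so it offers only a rough guide, and a smaller rise in the same direction is expected. The expected change is a number 0.30 log units higher from compound 2 to compound 3 (within the scatter). In this assay, compound 3 is estimated at 2.9, with an expected range from 2.5 to 3.3.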

Compound 3, distribution coefficient: 2.4
Compound 3: the middle estimate sits 0.50 log units above what was measured; the measured number lies below the stated range.
By their numbers in this assay, from the lowest: compound 1; then compounds 3 and 2 (each within the scatter of the next).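

In this assay the change from the single heavy atom of chloro to the four of trifluoromethyl gives a number 0.20 log units lower from compound 2 to compound 3 (within the scatter) and so leaves the two groups indistinguishable at this position. Fluoro stands apart from both, with a number 0.40 log units higher from compound 1 to compound 3 (beyond the scatter) as the second step away from it, so adding heavy atoms here does not simply raise the number. Nothing available explains why these groups fall as they do.

Going by these compounds, whether a nitrile or a methyl on this carbon would sit with fluoro or with chloro and trifluoromethyl remains open. So does the effect of an amine here.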